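Removing a Methyl From Compound 1: An Expected Small Step

The source may hold more compounds than are shown below. What is called first, only, known or untested is meant among the compounds shown, and "the series" means these compounds.

In a functional assay on A549 cells (Homo sapiens) for inhibition (a higher number here means a weaker inhibitor of growth, a lower number a stronger inhibitor of growth), compound 1 `C/C=C/C=C/C(=O)C[C@H](CCO)OC` gives 50000 nM, the second highest of the three numbers measured. Compound 3 `C/C=C/CCC(=O)C[C@@H](O)CCO` gives 54000 nM and compound 2 `C/C=C/C=C/C(=O)CC(CCO)OCC[C@H](O)CC(=O)/C=C/C=C/C` gives 29000 nM; both sit within the usual scatter of the number for compound 1, so no order among the three can be read from them. Compound 4 `C/C=C/C=C/C(=O)C[C@@H](O)CCO` is compound 1 with one change: hydrogen in place of methyl on an oxygen on a saturated carbon, which read one bond further out is methoxy to hydroxy. Compound 3 also carries a hydroxy and with 54000 nM stands within the scatter of compound 1 at 50000 nM, so in this assay no step beyond the scatter is expected. The expected step is a 1.1-fold lower number from compound 1 to compound 4 (0.05 log units; within the scatter). Compound 4 is estimated at 45000 nM, within a range from 15000 nM to 140000 nM.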

Compound 4, concentration for 50% growth inhibition: 54000 nM
The estimate for compound 4 lay 1.2-fold (0.08 log units) below the measured number; measured number inside the range.
By their numbers in this assay, from the lowest: compounds 2, 1, 3 and 4 (each within the scatter of the next).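

Going by these compounds alone, replacing methoxy with hydroxy on this oxygen gives a 1.1-fold higher number from compound 1 to compound 4 (0.03 log units; within the scatter) in this assay and is the first comparison here between two compounds that differ in one place. In this pair, the methyl on this oxygen can be lost without moving the number beyond the usual scatter. No measurement shown here explains this result. From the compounds shown here alone, whether a larger group on this oxygen, such as benzyl, would also leave the number within the scatter remains open. So does the outcome of placing an amine here instead of the oxygen.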